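Same Amine Change on Two Related Urea Cores

The source may hold more compounds than are shown below. What is called first, only, known or untested is meant among the compounds shown, and "the series" means these compounds.

Compound 1 `CN1CCN(Cc2ccc(NC(=O)Nc3ccc4ncnc(Nc5cccc(C(F)(F)F)c5)c4c3)cc2)CC1` is the anchor of this small set. In a functional assay on A549 cells (Homo sapiens) for antiproliferative activity, read by MTT assay, with a stated time of 72 h (a higher number here means a weaker inhibitor, a lower number a stronger inhibitor), compound 1 gives 1650 nM. Compound 2 `C[C@@H](Nc1ncnc2ccc(NC(=O)Nc3ccc(CN4CCN(C)CC4)cc3)cc12)c1ccccc1` differs from it by 1-phenylethyl in place of 3-(trifluoromethyl)phenyl on a nitrogen on an aromatic ring. Compound 2 sits at the limit of this assay, > 10000 nM. The step of an at least 6.0-fold higher number from compound 1 to compound 2 (0.78 log units; beyond the scatter) is thus a loss whose full size is hidden by the limit of > 10000 nM in this assay, at which 2 of the 3 values shown sit.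

Compound 3 `CN1CCN(CCNC(=O)Nc2ccc3ncnc(Nc4cccc(C(F)(F)F)c4)c3c2)CC1` has a different core; the difference between the two cores is not broken down here. Compound 3 also sits at the limit of this assay, > 10000 nM.

Compound 4 `C[C@@H](Nc1ncnc2ccc(NC(=O)NCCN3CCN(C)CC3)cc12)c1ccccc1` has not been measured in this assay. It carries 1-phenylethyl in place of 3-(trifluoromethyl)phenyl on a nitrogen on an aromatic ring, the same change that separates compound 2 from compound 1. That earlier change gave an at least 6.0-fold higher number from compound 1 to compound 2 (0.78 log units; beyond the scatter), so compound 4 is expected to move no closer to the measurable range than compound 3. Compound 4 is therefore estimated at 30000 nM, within 10000 nM to 100000 nM, and most likely to be reported only as a limit. The expected step is a step that the limit leaves unreadable from compound 3 to compound 4.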

Compound 4, half-maximal inhibitory concentration: > 10000 nM
Compound 4: no number, only a limit (the forecaster's own chance of this, stated with the estimate: 90%); the middle value does not contradict the limit.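

The step from compound 3 to compound 4 cannot be read, as compound 4 also gives no number, and the reason lies in this: the limit of > 10000 nM in this assay, at which 3 of the 4 values shown sit. The compounds shown leave open whether 1-phenylethyl in place of 3-(trifluoromethyl)phenyl changes anything on the core of compound 3, and how weak compound 2, compound 3 and compound 4 really are.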